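Turning the Acid Side Chain from E to Z

This account rests on a few compounds, and the source may have more. Where it says the series, first, only, none or still open, it means among the compounds named here.

Measured so far in a functional assay on the whole organism for inhibition, with Artemia salina as the target; on this read-out higher numbers stand for weaker inhibition of growth and lower numbers for stronger inhibition of growth:
Compound 1 `CO[C@H]1C[C@H](O[Si](C)(C)C(C)(C)C)O[C@@H](C)/C1=C\C(=O)O` gives 0.002 ug/mL.
Compound 2 `C=CCOC(=O)/C=C1/[C@H](C)O[C@@H](O[Si](C)(C)C(C)(C)C)C[C@@H]1OC` gives 0.002 ug/mL.
Compound 3 `CO/N=C/C=C1\[C@H](C)O[C@@H](O[Si](C)(C)C(C)(C)C)C[C@@H]1OC` gives 0.01 ug/mL.

Compound 1 stands level with compound 2 at the digits given, and these two are together the lowest of the three numbers. Compound 3 is furthest from compound 1. Going by the values given here, the one measured step between single-point neighbours is a number 2.3 two-fold dilutions higher from compound 1 to compound 3 (beyond the scatter); there a group of 4 heavy atoms (2 carbon, 1 nitrogen, 1 oxygen; no ring) replaces a group of 3 heavy atoms (1 carbon, 2 oxygen; no ring) on a double-bonded chain carbon bound to a double-bonded ring carbon.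

Compound 4 `CO[C@H]1C[C@H](O[Si](C)(C)C(C)(C)C)O[C@@H](C)/C1=C/C(=O)O` has not been measured. (the two compounds have the same atoms and bonds and differ only in configuration as drawn: 1 of 4 stereo elements differ; a double bond is drawn E in compound 1 and Z in compound 4). Among the compounds with values here, no measured step bears on this change: the step to compound 3 swaps the attached group, and compound 2 differs from compound 1 in another way while matching it at the digits given. Nothing here shows what a change of geometry alone does, so the expectation is weakly held, leaning toward no shift beyond the scatter or a small loss. Compound 4 is therefore expected to give 0.005 ug/mL in this assay, with a range from 0.001 ug/mL to 0.04 ug/mL. That estimate is expected to mean a number 1.3 two-fold dilutions higher from compound 1 to compound 4 (within the scatter).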

Compound 4, minimum inhibitory concentration: 0.002 ug/mL
Compound 4: the middle estimate sits 1.3 two-fold dilutions above what was measured; low and high end bracket the measured number.
By their numbers in this assay, from the lowest: compounds 1, 2 and 4 (each within the scatter of the next); then compound 3.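

In this assay there is no change at the digits printed from compound 1 to compound 4 (within the scatter), so turning the double bond from E to Z leaves the number where it stood. This step tests geometry alone, and the reason is plain: the fact that compounds 1 and 4 differ only in the configuration as drawn. Hydrogen in place of allyl on an oxygen next to a carbonyl group gives no change at the digits printed from compound 2 to compound 4 (within the scatter), so the free acid and its allyl ester also cannot be told apart here, and of the changes shown only the swap of group that leads to compound 3 moves the number beyond the scatter.

Going by these compounds, whether geometry stays just as silent with another group on the double-bonded chain carbon, such as an amide or a nitrile, remains open. So does the effect of the same E to Z turn on the group carried by compound 3.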